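Shortening the fatty acyl chain of an amide ceramide analogue

The compounds below may be only part of what the source reports. "The series", "measured", "known", "first", "only" and "open" are said of these compounds alone.

Measured compounds:
Compound 1, `CCCCCCCCCCCCCC(=O)N[C@@H](CO)C[C@@H](O)c1ccccc1`, in a functional assay on CHO cells (Cricetulus griseus) for inhibition; a higher number here means a weaker inhibitor, a lower number a stronger inhibitor: 70 nM.
Compound 2, `CCCCCCCCCCCCCCCCC(=O)N[C@@H](CO)C[C@@H](O)c1ccccc1`, in this assay: > 1000 nM, which is a limit of the assay and not a number.
Compound 3, `CCCCCCCCCCCCC(=O)N[C@@H](CO)C[C@@H](O)c1ccccc1`, in this assay: 50 nM.

The three compounds share one core and differ only in the length of the saturated chain on the amide. Compound 2 reaches only the limit (the limit of > 1000 nM in this assay, at which 1 of the 3 values shown sits). Going from compound 2 to compound 1 the change is hydrogen in place of propyl on a saturated chain carbon, ten or more bonds along the chain from a carbonyl carbon, and it made a large step, an at least 14-fold lower number from compound 2 to compound 1 (1.15 log units; beyond the scatter). Going from compound 2 to compound 3 the change is hydrogen in place of butyl on a saturated chain carbon, ten or more bonds along the chain from a carbonyl carbon, with a step of an at least 20-fold lower number from compound 2 to compound 3 (1.30 log units; beyond the scatter). Between compound 1 and compound 3 the step is a 1.4-fold lower number from compound 1 to compound 3 (0.15 log units; within the scatter), which is within the scatter, so no order can be read between these two.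

Compound 4, `CCCCCCCCCC(=O)N[C@@H](CO)C[C@@H](O)c1ccccc1`, is not yet measured. It differs from compound 3 by hydrogen in place of propyl on a saturated chain carbon, nine bonds along the chain from a carbonyl carbon. Among the compounds with values here, this is the same kind of change as the one from compound 2 to compound 1. Whether a still shorter chain helps, hurts or changes nothing is not settled by the three measured compounds: the large step from compound 2 to compound 1 came from removing chain length at the long end, while the step from compound 1 to compound 3 was within the scatter. The expectation for compound 4 is therefore a step of about a 1.6-fold higher number from compound 3 to compound 4 (0.20 log units; within the scatter) from compound 3, with wide uncertainty. In this assay compound 4 is estimated at 80 nM, expected between 20 nM and 400 nM.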

Compound 4, half-maximal inhibitory concentration: 300 nM
Beside the measured number, compound 4's estimate is 3.8-fold (0.57 log units) below it; the measured number falls inside the stated range.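

In this assay, cutting propyl from the chain does not behave the same on the two starting compounds: at the short end it gives a 6.0-fold higher number from compound 3 to compound 4 (0.78 log units; beyond the scatter), the opposite direction to the step seen at the long end: the same change on two cores in this assay, an at least 14-fold lower number (1.15 log units; beyond the scatter) from compound 2 to compound 1 and a 6.0-fold higher number (0.78 log units; beyond the scatter) from compound 3 to compound 4, at least 85-fold (1.93 log units) apart, beyond the scatter of two such steps

Removing butyl tells the same story, since a 4.3-fold higher number from compound 1 to compound 4 (0.63 log units; beyond the scatter) also runs against the earlier step: the same change on two cores in this assay, an at least 20-fold lower number (1.30 log units; beyond the scatter) from compound 2 to compound 3 and a 4.3-fold higher number (0.63 log units; beyond the scatter) from compound 1 to compound 4, at least 85-fold (1.93 log units) apart, beyond the scatter of two such steps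

Compound 2 stands at a limit and not a number, so an at least 3.3-fold lower number from compound 2 to compound 4 (0.52 log units; beyond the scatter) fixes only the smallest size that step can have, and none of these pairs shows why the direction of the change depends on the chain it is made on: the limit of > 1000 nM in this assay, at which 1 of the 4 values shown sits.

On these data alone, a chain longer than that of compound 4 but shorter than that of compound 3 remains open, so the point where shortening stops being harmless cannot be placed more closely. Also open, as far as these compounds go, are a chain shorter than that of compound 4 and a chain carrying a double bond, an ether oxygen, an amine or a carboxylic acid.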